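The source may report more compounds than this note shows. Statements on the series, on what has been measured and on what is new or still open speak of the compounds shown alone.

Two compounds of the series have numbers in a functional assay on the whole organism for inhibition of sodium-dependent dopamine transporter (Mus musculus); on this read-out higher numbers stand for an effect only at larger amounts of compound and lower numbers for an effect already at smaller amounts. Compound 1 `CC(C)c1ccc(C2CN(C)Cc3c(N)cccc32)cc1` gives about 65 mg/kg. Compound 2 `CCOC(=O)Nc1cccc2c1CN(C)CC2c1ccccc1` gives 2.5 mg/kg in this assay, the lowest of the two numbers, with compound 1 standing beyond the scatter above it. Compound 3 `CN1Cc2c(NC(=O)CN3CCCC3)cccc2C(c2ccccc2)C1` is not yet measured. It differs from compound 2 in one place: (pyrrolidin-1-yl)methyl in place of ethoxy on a carbonyl carbon. The ethoxy on the carbonyl carbon gives way to (pyrrolidin-1-yl)methyl, bringing one five-membered non-aromatic ring. Among the measured compounds shown here, no measured pair shows this change, so the step of a 2.4-fold higher number from compound 2 to compound 3 (0.38 log units; beyond the scatter) is an expectation only: a modest rise, not far beyond the scatter. For compound 3 in this assay the estimate is 6 mg/kg, within 1.5 mg/kg to 25 mg/kg.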

Compound 3, dose for half-maximal effect: 45 mg/kg
Compound 3: middle estimate off by 7.5-fold (0.88 log units), on the low side, outside the stated range (above it).
By their numbers in this assay, from the lowest: compound 2; then compounds 3 and 1 (each within the scatter of the next).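

In this assay the carbonyl carbon on the amide-type nitrogen is a sensitive place; (pyrrolidin-1-yl)methyl in place of ethoxy brings an 18-fold higher number from compound 2 to compound 3 (1.26 log units; beyond the scatter) and this step is large. The low number of compound 2 does not carry over to this replacement, so ethoxy cannot be exchanged freely here. No available evidence bears on the size of this step.

Still open, on these data alone, is whether the ring or its nitrogen goes with the step. Also open, as far as these compounds go, is how methoxy, propoxy or a dimethylaminomethyl group on the same carbonyl carbon would read.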